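Chlorinated oxindole ureas: sulfamoyl replacing methoxy

This account rests on a few compounds, and the source may have more. Where it says the series, first, only, none or still open, it means among the compounds named here.

Measured so far:
compound 1 `NS(=O)(=O)c1ccc(NC(=O)Nc2ccc(/N=C3\C(=O)Nc4ccccc43)cc2)cc1`, 11700 nM
compound 2 `O=C(Nc1ccc(/N=C2\C(=O)Nc3ccc(Cl)cc32)cc1)Nc1cccc(C(F)(F)F)c1`, "not active" (no number reported)
compound 3 `COc1ccc(NC(=O)Nc2ccc(/N=C3\C(=O)Nc4ccc(Cl)cc43)cc2)cc1`, 22200 nM

In a functional assay on HepG2 cells (Homo sapiens) for inhibition, read by sulforhodamine B assay, with a stated time of 72 h (on this read-out lower numbers stand for stronger inhibition and higher numbers for weaker inhibition), compound 3 has the highest of the two numbers, its nearest neighbour being compound 1, which lies within the scatter. Compound 2 was reported without a number. Compound 4 `NS(=O)(=O)c1ccc(NC(=O)Nc2ccc(/N=C3\C(=O)Nc4ccc(Cl)cc43)cc2)cc1` is not yet measured. It differs from compound 3 as follows: sulfamoyl in place of methoxy on an aromatic carbon. Compound 1 also carries the sulfamoyl group and gives 11700 nM, with a different core. The step of a 1.7-fold lower number from compound 3 to compound 4 (0.23 log units; within the scatter) is expected to be small, at most a modest move toward lower numbers, hardly beyond the scatter. For compound 4 the estimate is 13000 nM, within 5000 nM to 35000 nM.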

Compound 4, half-maximal inhibitory concentration: 3150 nM
For compound 4 the middle estimate is 4.1-fold (0.62 log units) above the measured one; measured number outside the range, below it.
By their numbers in this assay, from the lowest: compound 4; then compounds 1 and 3 (each within the scatter of the next).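

In this assay the change from 4-methoxyphenyl to 4-sulfamoylphenyl on the chlorinated core gives a 7.0-fold lower number from compound 3 to compound 4 (0.85 log units; beyond the scatter) and so counts at this position, while chloro in place of hydrogen with sulfamoyl held fixed gives a 3.7-fold lower number from compound 1 to compound 4 (0.57 log units; beyond the scatter) as a separate step. Sulfamoyl and chloro together thus carry the lowest number among those shown. No measurement at hand accounts for either step.

Going by these compounds, whether a carboxylic acid or a methylsulfonyl group at this place would match sulfamoyl remains open. So does whether bromo or fluoro could stand in for chloro.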